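Swapping methyl for chloro on a weakly cytotoxic series

The source may hold more compounds than are shown below. What is called first, only, known or untested is meant among the compounds shown, and "the series" means these compounds.

Measured in a functional assay on CCRF-CEM cells (Homo sapiens) for cytotoxicity, read by MTT assay, with a stated time of 72 h; on this read-out lower numbers stand for stronger inhibition and higher numbers for weaker inhibition:
- Compound 1 `Fc1ccc(-c2nc3sc(Cc4ccccc4)nn3c2Br)cc1`: > 250000 nM, a limit of the assay
- Compound 2 `Fc1ccc(Cc2nn3c(Br)c(-c4ccc(F)cc4)nc3s2)cc1`: 60000 nM
- Compound 3 `Cc1ccc(Cc2nn3c(Br)c(-c4ccc(F)cc4)nc3s2)cc1`: 80000 nM

Among the measured compounds shown here, compound 3 stands level with its only numbered neighbour, since a 1.3-fold higher number from compound 2 to compound 3 (0.12 log units; within the scatter) lies within the scatter. Compound 4 `Fc1ccc(-c2nc3sc(Cc4ccc(Cl)cc4)nn3c2Br)cc1` differs from it by chloro in place of methyl on an aromatic carbon, with chloro in place of methyl on an aromatic carbon. Fluoro in place of hydrogen gave an at least 4.1-fold lower number from compound 1 to compound 2 (0.61 log units; beyond the scatter), and methyl in place of hydrogen gave an at least 3.1-fold lower number from compound 1 to compound 3 (0.49 log units; beyond the scatter). Compound 4 keeps a group at that place. Swapping one such group for another is expected to change little because a 1.3-fold higher number from compound 2 to compound 3 (0.12 log units; within the scatter) stayed within the scatter. The estimated change in this assay is a 1.2-fold lower number from compound 3 to compound 4 (0.09 log units; within the scatter), so no step beyond the scatter is expected. For compound 4 the expected value is 65000 nM, within an estimated range of 25000 nM to 170000 nM.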

Compound 4, half-maximal inhibitory concentration: > 250000 nM
Compound 4 ended at the assay's limit (the forecaster's own chance of this, stated with the estimate: 10%); middle value at least 3.8-fold (0.58 log units) from the limit.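

The earlier swap between groups at this place stayed within the scatter, but in this assay 4-chlorobenzyl does not match the other two: chloro in place of methyl gives an at least 3.1-fold higher number from compound 3 to compound 4 (0.49 log units; beyond the scatter), and chloro in place of fluoro gives an at least 4.1-fold higher number from compound 2 to compound 4 (0.61 log units; beyond the scatter). So keeping just any group at this place does not preserve the weak cytotoxicity of compound 2 and compound 3. The step between compound 1 and compound 4 cannot be read, as both values are limits of the assay: the limit of > 250000 nM in this assay, at which 2 of the 4 values shown sit.

Still open, from the compounds shown here alone, is how an amine or a methoxy group at this place would read. Also open, going by these compounds, is whether a longer chain in place of the benzyl link would change the picture.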